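A few compounds are considered here, and "the series" means these few. Any claim that something is new, unique, unknown or untested is made for them only; others in the source may bear on it.

Measured compounds:
Compound 1 `CC[C@H](CCn1cncn1)c1ccc(C)cc1` gives 85.2 ug/mL in an ADME assay on RD cells (Homo sapiens) for cytotoxicity, read by MTT assay, with a stated time of 3 days; a higher number here means that more compound is tolerated, a lower number that less compound is tolerated.
Compound 2 `CC[C@@H](CCn1cncn1)c1ccc(C)cc1` gives 79.4 ug/mL in this assay.
Compound 3 `c1ccc(C[C@H](CCn2cncn2)c2ccccc2)cc1` gives 55.4 ug/mL in this assay.

Compound 3 sits close to the other two: its gap to compound 2 and its gap to compound 1 both fall within the usual scatter of this assay, so the three numbers cannot be told apart with confidence.

Compound 4 `c1ccc(C[C@@H](CCn2cncn2)c2ccccc2)cc1` has not yet been measured. It differs from compound 3 in one respect only: the two compounds have the same atoms and bonds and differ only in configuration as drawn: 1 of 1 stereo elements differ; a stereocentre at a saturated chain carbon is drawn R in compound 3 and S in compound 4.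

For the measured compounds named here, one measured step bears directly on this change. Compounds 1 and 2 are related in the very same way, because of the fact that compounds 1 and 2 differ only in the configuration as drawn, and the step of a 1.1-fold lower number from compound 1 to compound 2 (0.03 log units; within the scatter) was negligible. Turning the stereocentre around in that pair therefore left the tolerated concentration where it was.

On that basis compound 4 is expected to give about 55 ug/mL, most likely between 35 ug/mL and 90 ug/mL. The expected step of a 1.0-fold lower number from compound 3 to compound 4 (0.00 log units; within the scatter) is estimated to be none beyond the scatter.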

Compound 4, half-maximal cytotoxic concentration: 56 ug/mL
Estimate against measurement, compound 4: 1.0-fold (0.01 log units) below, and the stated range covers the measured number.
By their numbers in this assay, from the lowest: compounds 3, 4, 2 and 1 (each within the scatter of the next).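

The stereocentre's configuration now has a second test, on a pair that carries different groups from compounds 1 and 2: the fact that compounds 3 and 4 differ only in the configuration as drawn

In this assay, the change gives a 1.0-fold higher number from compound 3 to compound 4 (0.00 log units; within the scatter), so the tolerated concentration again shows no dependence on how the stereocentre is drawn. Both mirror-image pairs now agree and neither goes against this pattern, which makes the earlier result less likely to be a peculiarity of compounds 1 and 2.

For the compounds shown here, still, these two pairs are the only evidence, so it remains open whether configuration would stay equally without consequence in a compound carrying an amine or a carboxylic acid. This read-out concerns tolerance by these cells alone, so it leaves open whether the two configurations would also match in any other kind of test.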